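The source may hold more compounds than are shown below. What is called first, only, known or untested is meant among the compounds shown, and "the series" means these compounds.

Of the compounds shown here, three of a shared core have been measured in a functional assay on MIA PaCa-2 cells (Homo sapiens) for inhibition, read by MTT assay, with a stated time of 72 h; on this read-out lower numbers stand for stronger inhibition and higher numbers for weaker inhibition. Compound 1 `COc1cc(NC(C)CCCNC(=O)NNC(=O)Nc2cccc(F)c2)c2ncccc2c1` gives 69000 nM, compound 2 `COc1cc(NC(C)CCCNC(=O)Nc2ccc(C(F)(F)F)cc2)c2ncccc2c1` gives 8400 nM, and compound 3 `COc1cc(NC(C)CCCNC(=O)NNC(=O)Nc2cccc(Cl)c2)c2ncccc2c1` gives 74000 nM. Compound 3 therefore shows the highest number of the three, with compound 1 nearest, a gap within the scatter, and compound 2 furthest, a gap beyond it.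

Compound 4 `COc1cc(NC(C)CCCNC(=O)Nc2cccc(Cl)c2)c2ncccc2c1` differs from compound 3 in one place: 3-chlorophenyl in place of ((3-chlorophenyl)carbamoyl)amino on an amide-type nitrogen. Among the measured compounds shown here, two measured steps bear on this exchange of a carbamoylamino link for a direct aryl group. The step of an 8.2-fold lower number from compound 1 to compound 2 (0.91 log units; beyond the scatter) and the step of an 8.8-fold higher number from compound 2 to compound 3 (0.94 log units; beyond the scatter) both carry a substituent change on the aryl ring as well, but the step of a 1.1-fold higher number from compound 1 to compound 3 (0.03 log units; within the scatter) shows that swapping fluoro for chloro alone stays within the scatter. The shortening is therefore expected to lower the number in this assay by a modest step, similar in size to those two.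

For compound 4 the estimate is 9000 nM, with a range from 3000 nM to 30000 nM, which amounts to an expected step of an 8.2-fold lower number from compound 3 to compound 4 (0.91 log units; beyond the scatter).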

Compound 4, half-maximal inhibitory concentration: 21000 nM
Compound 4: the middle estimate sits 2.3-fold (0.37 log units) below what was measured; the measured number falls inside the stated range.
By their numbers in this assay, from the lowest: compound 2; then compound 4; then compounds 1 and 3 (each within the scatter of the next).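

Among the compounds shown here, with the 3-chlorophenyl ring held constant, removing the carbamoylamino link on the amide-type nitrogen gives in this assay a 3.5-fold lower number from compound 3 to compound 4 (0.55 log units; beyond the scatter) and so isolates this shortening for the first time, free of any change on the aryl ring. The direct aryl group also matters in its own right: 3-chlorophenyl in place of 4-(trifluoromethyl)phenyl gives a 2.5-fold higher number from compound 2 to compound 4 (0.40 log units; beyond the scatter) and shows that the ring on the shortened urea still moves the number, while the step of a 3.3-fold lower number from compound 1 to compound 4 (0.52 log units; beyond the scatter) points the same way as the shortening, though it also exchanges fluoro for chloro. Nothing available here explains these steps.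

Whether the shortening gives a similar step with the 4-(trifluoromethyl)phenyl ring remains open, since compound 2 has no carbamoylamino partner among these compounds. Also open, on these data alone, is how a benzyl group, or a phenyl ring carrying a carboxylic acid or an amine, would behave on this nitrogen.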